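Thiomorpholinyl in place of morpholinyl: stability expectation

The compounds below may be only part of what the source reports. "The series", "measured", "known", "first", "only" and "open" are said of these compounds alone.

Compound 1 `CC(C)(C)c1cc(NC(=O)[C@@H]2CCCCN2Cc2ccc(Cl)cc2)no1` carries a 4-chlorobenzyl group on the ring amine nitrogen. In an ADME assay (liver) for metabolic stability, with Liver microsome (Homo sapiens) as the target, read by LC-MS, using microsomes and NADPH, tested at 1 uM (a higher number here means that the compound lasts longer, a lower number that the compound disappears faster), compound 1 gives 0.15 h. Compound 2 `CC(C)(C)c1cc(NC(=O)[C@@H]2CCCCN2C(=O)N2CCOCC2)no1` carries a (morpholin-4-yl)carbonyl group in that place. In this assay compound 2 gives > 2 h, which is a limit of the assay and not a number. Going by the values given here, the single measured step, an at least 13-fold higher number from compound 1 to compound 2 (1.12 log units; beyond the scatter), thus ends at the limit of > 2 h in this assay, at which 1 of the 2 values shown sits, and compound 2 stands at the top of what has been measured, with no number beyond it.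

Compound 3 `CC(C)(C)c1cc(NC(=O)[C@@H]2CCCCN2C(=O)N2CCSCC2)no1` differs from compound 2 by thiomorpholin-4-yl in place of morpholin-4-yl on a carbonyl carbon. Among the compounds with values here, no measured step bears on this exchange: the step from compound 1 to compound 2 alters the group on the ring amine nitrogen as a whole and says nothing about swapping one ring hetero atom for another within the carbonyl-linked ring. The expectation therefore rests on the position of compound 2 alone and carries wide uncertainty. For compound 3 the expected step is an at least 1.6-fold lower number from compound 2 to compound 3 (0.22 log units; that floor lies within the scatter), with a fair chance that only a limit is reported again. Compound 3 is estimated in this assay at 1.2 h, with a range from 0.3 h to 2 h.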

Compound 3, half-life: < 0.0834 h
Compound 3 gave a limit, no number; the forecaster's own chance of this, stated with the estimate: 40%; middle value at least 14-fold (1.15 log units) away from the limit.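

The hetero atom in the ring of the carbonyl-linked group matters a great deal in this assay: with all else held, sulfur in place of oxygen gives an at least 23-fold lower number from compound 2 to compound 3 (1.37 log units; beyond the scatter). A carbonyl-linked ring in place of 4-chlorobenzyl therefore does not by itself secure a long half-life, as the (thiomorpholin-4-yl)carbonyl group gives an at least 1.7-fold lower number from compound 1 to compound 3 (0.25 log units; that floor lies within the scatter), so the high end of the series rests on the (morpholin-4-yl)carbonyl group alone among the groups shown. Compound 3 gives < 0.0834 h, which is a limit of the assay and not a number, and the true size of both steps stays unknown, with the exchange bounded at each end by a limit: the limit of < 0.0834 h in this assay, at which 1 of the 3 values shown sits.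

The values give no reason for the difference between the two rings, and they do not show whether it belongs to the ring sulfur itself or would persist with that sulfur carried as a sulfone. Also open, as far as these compounds go, is where rings with other atoms at that ring position would fall, such as piperidin-1-yl with a plain carbon or piperazin-1-yl with a second nitrogen, on the same carbonyl carbon.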